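Swapping a Thiophene Arm for a Bromophenyl Arm

The source may hold more compounds than are shown below. What is called first, only, known or untested is meant among the compounds shown, and "the series" means these compounds.

Of the compounds shown here, three built on one shared core have been tested in a functional assay on A498 cells (Homo sapiens) for inhibition, read by sulforhodamine B assay, with a stated time of 48 h, tested at 10 uM; on this read-out lower numbers stand for less inhibition and higher numbers for more inhibition at the one concentration tested (going by the name of the read-out). Compound 1 `c1ccc(-c2cn3ccnc3c(-c3ccc4ncn(C5CCCCC5)c4c3)n2)cc1` gives 26.1%. Compound 2 `O=Cc1ccc(-c2cn3ccnc3c(-c3ccc4ncn(C5CCCCC5)c4c3)n2)cc1`, which carries a formyl group on its phenyl ring, gives 11.2%. Compound 3 `c1cn2cc(-c3ccsc3)nc(-c3ccc4ncn(C5CCCCC5)c4c3)c2n1` gives 20.1%. Among these three numbers compound 3 stands second highest, but the steps of a number 6 percentage points lower from compound 1 to compound 3 (within the scatter) and a number 8.9 percentage points higher from compound 2 to compound 3 (within the scatter) are both within the usual scatter of this kind of measurement, so the three cannot be ranked with confidence.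

Compound 4 `Brc1ccc(-c2cn3ccnc3c(-c3ccc4ncn(C5CCCCC5)c4c3)n2)cc1` has not yet been measured. It differs from compound 3 in one place: 4-bromophenyl in place of thiophen-3-yl on an aromatic carbon. Among the compounds with values here, two measured steps bear on this change. The exchange of phenyl for thiophen-3-yl, a number 6 percentage points lower from compound 1 to compound 3 (within the scatter), hardly moved the reading, so a six-membered ring of carbon only and the five-membered ring gave similar numbers here. Adding a formyl group to the phenyl ring, a number 14.9 percentage points lower from compound 1 to compound 2 (beyond the scatter), lowered the reading beyond the scatter. Bromine is a different group from formyl, and no measured compound carries it, so its effect is uncertain. On balance the expected step is a number 1.9 percentage points higher from compound 3 to compound 4 (within the scatter). The estimate for compound 4 is therefore 22%, with a range from 8% to 36%.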

Compound 4, a percentage reported as inhibition, at one concentration (the size of the read-out at that concentration, not a potency): 20.7%
Compound 4: middle estimate off by 1.3 percentage points, on the high side; the measured number falls inside the stated range.
By their numbers in this assay, from the lowest: compounds 2, 3, 4 and 1 (each within the scatter of the next, the first and the last beyond it).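

In this assay, exchanging the thiophen-3-yl arm for the 4-bromophenyl arm on this aromatic carbon gives no reading that can be told apart (a number 0.6 percentage points higher from compound 3 to compound 4 (within the scatter)), so a sulfur-containing five-membered ring and a bromine-bearing six-membered ring of carbon only serve equally well as far as this measurement can show. The bromo group also adds something the formyl result could not show: a group on the phenyl ring does not always bring a drop beyond the scatter, since bromo in place of hydrogen stays within it (a number 5.4 percentage points lower from compound 1 to compound 4 (within the scatter)), and so does bromo in place of formyl (a number 9.5 percentage points higher from compound 2 to compound 4 (within the scatter)), which leaves compound 4 unresolved from both compound 1 and compound 2. Nothing in the available data explains why these arms read alike.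

Every arm shown is an aromatic ring, and the only groups on the phenyl ring are formyl and bromo, so it remains open how an amine, a carboxylic acid or a longer chain on that ring would read. The readings also come from one concentration only, so they say nothing about how potency would compare across these compounds.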